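The source may hold more compounds than are shown below. What is called first, only, known or untested is meant among the compounds shown, and "the series" means these compounds.

Working notes on the sulfonate series in a functional assay on MCF7 cells (Homo sapiens) for antiproliferative activity, read by sulforhodamine B assay, with a stated time of 48 h; a lower number here means a stronger inhibitor, a higher number a weaker inhibitor.

Compound 2 `COc1ccc(OS(=O)(=O)c2ccc(N3CCN(C)C3=O)cc2)cc1` gives 95000 nM. Compound 1 `COc1ccc(OS(=O)(=O)c2ccc(N3CCN(C)C3=O)cc2)cc1OC` gives 12000 nM. The change between them is methoxy in place of hydrogen on an aromatic carbon and it made the step of a 7.9-fold lower number from compound 2 to compound 1 (0.90 log units; beyond the scatter).

Compound 3 `CCCN1CCN(c2ccc(S(=O)(=O)Oc3cc(OC)cc(OC)c3)cc2)C1=O` gives 270 nM, the lowest number of the three measured; the difference between its core and the core of compound 2 is not broken down here.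

Compound 4 `CCCN1CCN(c2ccc(S(=O)(=O)Oc3cc(OC)c(OC)c(OC)c3)cc2)C1=O` is not yet measured in this assay. It differs from compound 3 by methoxy in place of hydrogen on an aromatic carbon. This is the same kind of change as that from compound 2 to compound 1, but the surroundings differ: there the entering group was ortho to a methoxy group and meta to a large group, here it is ortho to two methoxy groups and para to a large group.

On the strength of the earlier step of a 7.9-fold lower number from compound 2 to compound 1 (0.90 log units; beyond the scatter), the expected step is a 3.9-fold lower number from compound 3 to compound 4 (0.59 log units; beyond the scatter), somewhat smaller since the surroundings are not the same. Compound 4 is therefore estimated at 70 nM, with a likely range from 15 nM to 300 nM.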

Compound 4, half-maximal inhibitory concentration: 49 nM
For compound 4 the middle estimate is 1.4-fold (0.15 log units) above the measured one; the measured number falls inside the stated range.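

In this assay, methoxy in place of hydrogen on an aromatic carbon again lowers the number, giving a 5.5-fold lower number from compound 3 to compound 4 (0.74 log units; beyond the scatter), and the two steps agree across the two cores: the same change on two cores in this assay, a 7.9-fold lower number (0.90 log units; beyond the scatter) from compound 2 to compound 1 and a 5.5-fold lower number (0.74 log units; beyond the scatter) from compound 3 to compound 4, 1.4-fold (0.16 log units) apart, within the scatter of two such steps. Within these two pairs, the change therefore carries from one core to the other with its direction and approximate size intact, even though the surroundings of the entering group are not the same. This rests on only two steps, so it does not show that the change would carry to any further core, nor does it explain the lowering or separate the contribution of the core, for which no single-change pair is shown.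

As far as these compounds go, it remains open whether an ethoxy group, a hydroxyl group or an amine in place of the entering methoxy would give a step of similar size. Also open, from the compounds shown here alone, is how a longer chain on the nitrogen of the core of compound 4 would affect the number.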